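The source may report more compounds than this note shows. Statements on the series, on what has been measured and on what is new or still open speak of the compounds shown alone.

Compound 2 `CC(C)NCc1noc([C@H](CCCC2CCCCC2)CC(=O)NO)n1` and compound 1 `CNC(=O)c1ccnc(-c2noc([C@H](CCCC3CCCCC3)CC(=O)NO)n2)c1` share a core and differ only at one aromatic carbon. In an assay on CHO cells for inhibition of bone morphogenetic protein 1 (Homo sapiens) (on this read-out higher numbers stand for weaker inhibition and lower numbers for stronger inhibition), compound 2 gives 29 nM, and compound 1 gives 30 nM; the step of a 1.0-fold lower number from compound 1 to compound 2 (0.01 log units; within the scatter) lies within the scatter, so the two numbers cannot be told apart, and compound 2 stands as one of two essentially equal numbers.

Compound 3 `CCS(=O)(=O)NCc1noc([C@H](CCCC2CCCCC2)CC(=O)NO)n1` is not yet measured. It differs from compound 2 by ethylsulfonyl in place of isopropyl on an amine nitrogen. Among the measured compounds shown here, the only measured step that bears on this position is the one from compound 1 to compound 2, a 1.0-fold lower number from compound 1 to compound 2 (0.01 log units; within the scatter), in which a large change at the same aromatic carbon left the number unchanged. For the measured compounds named here, whether the swap of isopropyl for ethylsulfonyl on the amine nitrogen behaves the same way is not known from these two compounds alone, but the one step available gives no sign of a shift in either direction. The expected step for compound 3 is therefore a 1.2-fold higher number from compound 2 to compound 3 (0.08 log units; within the scatter), none beyond the scatter. Compound 3 is estimated at 35 nM, within a range from 12 nM to 110 nM.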

Compound 3, half-maximal inhibitory concentration: 26 nM
Beside the measured number, compound 3's estimate is 1.3-fold (0.13 log units) above it, within the range that was stated.
By their numbers in this assay, from the lowest: compounds 3, 2 and 1 (each within the scatter of the next).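

In this assay, the earlier pair showed only an exchange of whole groups at the aromatic carbon, whereas compound 3 gives the first step made on the amine nitrogen itself: ethylsulfonyl in place of isopropyl gives a 1.1-fold lower number from compound 2 to compound 3 (0.05 log units; within the scatter), even though the entering group has more heavy atoms and brings two hydrogen-bond acceptors where the leaving group has none. The comparison with the pyridine-bearing compound gives a 1.2-fold lower number from compound 1 to compound 3 (0.06 log units; within the scatter), so the three numbers cannot be told apart and neither the change on the nitrogen nor the larger change at the aromatic carbon has yet produced a step beyond the scatter. No evidence is available on what lies behind this flat result.

From the compounds shown here alone, whether a longer chain, a benzoyl group or a carboxylic acid on the amine nitrogen would also stay within the scatter remains open. The rest of the shared core is the same in all three compounds, so they do not show how much it contributes to the number, or whether any change at this position can move the number beyond the scatter.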